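Phenyl to Pyrimidinyl on the Piperazine Nitrogen

The source may hold more compounds than are shown below. What is called first, only, known or untested is meant among the compounds shown, and "the series" means these compounds.

Compound 1 `CN1CCN(CCCc2c[nH]c3ccc(-n4cnnc4)cc23)CC1`: 309 nM
Compound 2 `c1ccc(N2CCN(CCCc3c[nH]c4ccc(-n5cnnc5)cc34)CC2)cc1`: 13 nM

Both compounds share a core in which a ring nitrogen carries a substituent, and both were tested in an assay on CHO cells for displacement of a labelled ligand from 5-hydroxytryptamine receptor 1B (Homo sapiens); on this read-out higher numbers stand for weaker inhibition and lower numbers for stronger inhibition. Compound 1 gives 309 nM, while compound 2 gives 13 nM. For the measured compounds named here, the single step between them, a 24-fold lower number from compound 1 to compound 2 (1.38 log units; beyond the scatter), describes the move from a methyl to a phenyl on that nitrogen. Compound 2 thus has the lowest number of the two shown, with compound 1 as its only neighbour at a higher number.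

Compound 3 `c1cnc(N2CCN(CCCc3c[nH]c4ccc(-n5cnnc5)cc34)CC2)nc1` is the next step: pyrimidin-2-yl in place of phenyl on an amine nitrogen in a ring. Going by the values given here, no measured step covers this kind of change, so the earlier step gives only indirect guidance; it shows that a six-membered aromatic ring on the nitrogen is compatible with a low number, but says nothing about swapping one such ring for another. For that reason the step of a 1.9-fold higher number from compound 2 to compound 3 (0.28 log units; within the scatter) is expected to be modest and could fall within the scatter. Compound 3 is therefore estimated at 25 nM, with a range from 6 nM to 100 nM.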

Compound 3, half-maximal inhibitory concentration: 0.5 nM
The estimate for compound 3 lay 50-fold (1.70 log units) above the measured number; measured number below the stated range.
By their numbers in this assay, from the lowest: compound 3; then compound 2; then compound 1.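

Swapping one six-membered aromatic ring for another on this amine nitrogen is far from a neutral exchange: in this assay, the change gives a 26-fold lower number from compound 2 to compound 3 (1.41 log units; beyond the scatter), even though phenyl and pyrimidin-2-yl both have 6 heavy atoms and differ in that two ring carbons become nitrogens, which adds 2 hydrogen-bond acceptors by the count. The identity of the aromatic ring therefore matters here as well as its presence, and taken from the methyl group the full change is a 620-fold lower number from compound 1 to compound 3 (2.79 log units; beyond the scatter), which makes compound 3 the most potent of the three in this read-out. Nothing measured here explains why the pyrimidin-2-yl group gives so much lower a number than phenyl.

The compounds shown leave open whether both ring nitrogens are needed, and a pyridin-2-yl group, with a single ring nitrogen, would help to separate their contributions. Also open, on these data alone, is how a pyrazin-2-yl group, or a methoxy group added to the pyrimidine ring, would change the number.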